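This account rests on a few compounds, and the source may have more. Where it says the series, first, only, none or still open, it means among the compounds named here.

Measured compounds:
Compound 1 `c1ccc(-c2cn3ccnc3c(-c3ccc4ncn(C5CCCCC5)c4c3)n2)cc1` gives 21.7% in a functional assay on SF-268 cells (Homo sapiens) for inhibition, read by sulforhodamine B assay, with a stated time of 48 h, tested at 10 uM; a higher number here means more inhibition at the concentration tested (going by the name of the read-out), a lower number less inhibition.
Compound 2 `O=Cc1ccc(-c2cn3ccnc3c(-c3ccc4ncn(C5CCCCC5)c4c3)n2)cc1` gives 27.1% in this assay.

Compound 2 has the higher of the two numbers in this assay, yet its gap to compound 1 is within the scatter, so the two cannot be ranked. Among the compounds with values here, the one measured step, a number 5.4 percentage points higher from compound 1 to compound 2 (within the scatter), changed nothing beyond the scatter.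

Compound 3 `c1ccc2c(-c3cn4ccnc4c(-c4ccc5ncn(C6CCCCC6)c5c4)n3)cccc2c1` has not yet been measured. It differs from compound 2 in one place: naphthalen-1-yl in place of 4-formylphenyl on an aromatic carbon. Within the data shown here, the only step measured so far is the one from compound 1 to compound 2, and it swapped a small group at the same place with no effect beyond the scatter. Nothing measured shows what two fused carbon rings do there, so no step beyond the scatter is expected; the step from compound 2 to compound 3 is estimated at a number 2.1 percentage points lower from compound 2 to compound 3 (within the scatter). Compound 3 is thus expected to give about 25% in this assay, within a range from 5% to 50%.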

Compound 3, a percentage reported as inhibition, at one concentration (the size of the read-out at that concentration, not a potency): 7.84%
Compound 3: middle estimate off by 17.2 percentage points, on the high side, and the stated range covers the measured number.
By their numbers in this assay, from the lowest: compound 3; then compounds 1 and 2 (each within the scatter of the next).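

Putting naphthalen-1-yl at this aromatic carbon of the shared core gives a number 19.3 percentage points lower from compound 2 to compound 3 (beyond the scatter) in this assay, and set against the plain phenyl group it gives a number 13.9 percentage points lower from compound 1 to compound 3 (beyond the scatter). So this position is not indifferent to every change: the formyl swap on the phenyl ring moved nothing beyond the scatter, whereas a group with two six-membered aromatic rings lowers inhibition at the concentration tested by a modest amount. Nothing available explains this drop.

The compounds shown leave open whether the drop belongs to the second ring itself or to the way it is attached, a question that a naphthalen-2-yl group on the same carbon could address. They also leave open how a phenyl ring carrying an amine or a carboxylic acid would behave here.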